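The compounds below may be only part of what the source reports. "The series", "measured", "known", "first", "only" and "open" are said of these compounds alone.

In a functional assay on SMMC-7721 cells (Homo sapiens) for antiproliferative activity, read by MTT assay, with a stated time of 72 h (on this read-out higher numbers stand for weaker inhibition and lower numbers for stronger inhibition), compound 3 `O=C(N/N=C/c1ccccn1)c1cccc(S(=O)(=O)N2CCOCC2)c1` gives no number. Its result of > 100000 nM is a limit of the assay. Compound 1 `C/C(=N\NC(=O)c1cccc(S(=O)(=O)N2CCOCC2)c1)c1cccc(N)c1` also gives only a limit, > 100000 nM.

Compound 4 `O=C(N/N=C/c1cc(Br)cc(Br)c1O)c1cccc(S(=O)(=O)N2CCOCC2)c1` differs from compound 3 in one place, where 3,5-dibromo-2-hydroxyphenyl takes the place of pyridin-2-yl on a carbon with a double bond to nitrogen: 3,5-dibromo-2-hydroxyphenyl in place of pyridin-2-yl on a carbon with a double bond to nitrogen.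

Within the data shown here, one measured step bears on this change. Compound 2 `C/C(=N\NC(=O)c1cccc(S(=O)(=O)N2CCOCC2)c1)c1cccc(N)c1O` carries hydroxy in place of hydrogen on an aromatic carbon and gives 2330 nM in this assay. That step, an at least 42-fold lower number from compound 1 to compound 2 (1.63 log units; beyond the scatter), is large and lies beyond the scatter. Among the measured compounds shown here, it is only a single pair with a different group around the hydroxy, and no measured step shows what bromine does.

Compound 4 also gains a hydroxy group, so the step seen with compound 2 at 2330 nM suggests a similar gain. The estimated change is an at least 33-fold lower number from compound 3 to compound 4 (1.52 log units; beyond the scatter), a large one toward stronger inhibition. Compound 4 is expected at about 3000 nM, with an estimated range from 500 nM to 20000 nM.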

Compound 4, half-maximal inhibitory concentration: 7310 nM
Compound 4: middle estimate off by 2.4-fold (0.39 log units), on the low side; the range from low to high includes it.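

In this assay, among these compounds, this is the first measured change at the group on the carbon with a double bond to nitrogen: an at least 13-fold lower number from compound 3 to compound 4 (1.13 log units; beyond the scatter). It is also the second step in which a group with a hydroxy brings a measurable value where the starting compound gave none, although here the whole ring changes, not just one hydrogen. Compound 3 gives only a limit, so the true size of this step cannot be read, because its starting point is not a number: the limit of > 100000 nM in this assay, at which 2 of the 4 values shown sit.

The hydroxy and the two bromines enter together, so the compounds shown do not reveal how much each contributes. As far as these compounds go, it remains open whether a plain phenyl, a 2-hydroxyphenyl without bromine, or a methoxy in place of the hydroxy would give a similar result.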